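A Swap of Ring Substituents on the Amine Nitrogen

The compounds below may be only part of what the source reports. "The series", "measured", "known", "first", "only" and "open" are said of these compounds alone.

Of the compounds shown here, three have so far been measured in a functional assay on CHO-K1 cells for agonist activity at Glucose-dependent insulinotropic receptor (Homo sapiens), read by HTRF and cAMP accumulation, with a stated time of 30 min; on this read-out higher numbers stand for larger maximal responses and lower numbers for smaller maximal responses. Compound 1 `CC(C)(C)OC(=O)N1CCC(CCCCNc2ccc3c(c2)CCS3(=O)=O)CC1` gives 62%, compound 2 `CC(C)(C)OC(=O)N1CCC(CCCNc2ccc3c(c2)CCS3(=O)=O)CC1` gives 80%, and compound 3 `COc1cnc(N2CCC(CCCNc3ccc4c(c3)OCC4=O)CC2)nc1` gives 101%. Compound 3 stands highest of the three: its gap to compound 2, the nearest, lies beyond the usual scatter, and its gap to compound 1, the furthest, is larger still.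

Compound 4 `CC(C)c1nnc(N2CCC(CCCNc3ccc4c(c3)OCC4=O)CC2)o1` is the next compound to be measured in this assay. It differs from compound 3 in one place: 5-isopropyl-1,3,4-oxadiazol-2-yl in place of 5-methoxypyrimidin-2-yl on an amine nitrogen in a ring. The group that leaves and the group that enters are equal in heavy-atom count and in the number of hydrogen-bond acceptors, with the six-membered aromatic ring giving way to a five-membered one.

For the measured compounds named here, no pair of measured compounds shows this change, so there is no measured step to lean on. For compound 4, the maximal response is expected to be close to that of compound 3, with the step from compound 3 to compound 4 estimated at a number 11 percentage points lower from compound 3 to compound 4 (beyond the scatter), a change that may not exceed the scatter. Compound 4 is expected to give 90%, within a range of 70% to 105%.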

Compound 4, largest response reached (Emax), in percent of the reference or control that the assay uses: 85%
Beside the measured number, compound 4's estimate is 5 percentage points above it; the measured number falls inside the stated range.
By their numbers in this assay, from the lowest: compound 1; then compounds 2 and 4 (each within the scatter of the next); then compound 3.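

In this assay, for the compounds shown here, replacing 5-methoxypyrimidin-2-yl with 5-isopropyl-1,3,4-oxadiazol-2-yl on the amine nitrogen in a ring gives the only measured step at this place, a number 16 percentage points lower from compound 3 to compound 4 (beyond the scatter) in a modest move. The two groups match in heavy-atom count and in hydrogen-bond acceptors, yet the maximal response still shifts beyond the scatter, so these counts alone do not set it here. With the five-membered aromatic ring in place, compound 4 still reaches 85% in this assay and no evidence at hand explains the step.

Ring and substituent change together in this step, and the compounds shown do not separate the two. From the compounds shown here alone, how a 5-methyl-1,3,4-oxadiazol-2-yl or an unsubstituted pyrimidin-2-yl group on the same nitrogen would behave remains open.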